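The source may hold more compounds than are shown below. What is called first, only, known or untested is meant among the compounds shown, and "the series" means these compounds.

Compound 2 `COc1ccc(S(=O)(=O)Nc2ccc(C)cc2Br)cc1N1CCNCC1` gives 7.94 nM in an assay on isolated protein for binding affinity to 5-hydroxytryptamine receptor 6 (Homo sapiens) (a higher number here means a weaker inhibitor, a lower number a stronger inhibitor), the highest of the three numbers: compound 1 `COc1ccc(S(=O)(=O)Nc2cc(Cl)cc(Cl)c2)cc1N1CCNCC1` gives 0.631 nM and compound 3 `COc1ccc(S(=O)(=O)Nc2cc(Cl)cc(Cl)c2Br)cc1N1CCNCC1` gives 3.16 nM. Compound 4 `COc1ccc(S(=O)(=O)Nc2cc(Br)cc(Br)c2Cl)cc1N1CCNCC1` differs from compound 2 by 3,5-dibromo-2-chlorophenyl in place of 2-bromo-4-methylphenyl on a sulfonamide nitrogen. Among the measured compounds shown here, two steps bear on it. The step of a 2.5-fold lower number from compound 2 to compound 3 (0.40 log units; beyond the scatter) sets a halogen-bearing phenyl of the same substitution pattern against the 2-bromo-4-methylphenyl, and the step of a 5.0-fold higher number from compound 1 to compound 3 (0.70 log units; beyond the scatter) shows what a halogen on that ring carbon does. Since compound 4 carries halogens in the same places as compound 3, a modest step downward from compound 2 is expected, a 2.6-fold lower number from compound 2 to compound 4 (0.42 log units; beyond the scatter), and compound 4 is estimated at 3 nM, between 1 nM and 10 nM.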

Compound 4, inhibition constant: 2.51 nM
Compound 4: the middle estimate sits 1.2-fold (0.08 log units) above what was measured; the measured number falls inside the stated range.
By their numbers in this assay, from the lowest: compound 1; then compounds 4 and 3 (each within the scatter of the next); then compound 2.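

In this assay, exchanging the halogens on the phenyl at the sulfonamide nitrogen makes no difference beyond the scatter (a 1.3-fold lower number from compound 3 to compound 4 (0.10 log units; within the scatter)). The 3,5-dibromo-2-chlorophenyl group still gives a better number than the 2-bromo-4-methylphenyl group (a 3.2-fold lower number from compound 2 to compound 4 (0.50 log units; beyond the scatter)), but a worse one than the 3,5-dichlorophenyl group (a 4.0-fold higher number from compound 1 to compound 4 (0.60 log units; beyond the scatter)), so this second trihalogenated ring matches compound 3 in falling short of compound 1. No measurement available here accounts for these steps. The compounds shown leave open how this position would respond to a ring carrying an amine or a carboxylic acid in place of the halogens.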